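The source may report more compounds than this note shows. Statements on the series, on what has been measured and on what is new or still open speak of the compounds shown alone.

Compound 2 `COc1ccccc1NS(=O)(=O)c1ccc(N2CCNC2=O)cc1` belongs to a small set of sulfonamides built on a shared core. In a functional assay on HT-29 cells (Homo sapiens) for antiproliferative activity, read by sulforhodamine B assay, with a stated time of 48 h (a lower number here means a stronger inhibitor, a higher number a weaker inhibitor), compound 2 gives 550 nM, the lowest of the two numbers in hand. Compound 1 `O=C1NCCN1c1ccc(S(=O)(=O)Nc2ccc(OC(F)F)cc2)cc1` is the nearest neighbour, and in this assay compound 1 gives 650 nM, a gap that lies within the scatter of the measurement. Compound 3 `CC(C)(C)c1ccc(NS(=O)(=O)c2ccc(N3CCNC3=O)cc2)cc1` reaches only a limit in this assay, > 1000 nM, which is not a number (the limit of > 1000 nM in this assay, at which 1 of the 3 values shown sits).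

Compound 4 `Cc1ccc(C)c(NS(=O)(=O)c2ccc(N3CCNC3=O)cc2)c1` has not yet been measured. It differs from compound 2 in one place: 2,5-dimethylphenyl in place of 2-methoxyphenyl on a sulfonamide nitrogen. For the measured compounds named here, the one measured step of a kindred sort, a methoxy-like group giving way to an all-carbon group on the same kind of ring, is an at least 1.5-fold higher number from compound 1 to compound 3 (0.18 log units; that floor lies within the scatter). From the compounds shown here alone, that step went toward a weaker inhibitor, though its floor sits within the scatter and its true size remains unknown. A rise of similar or somewhat larger size is therefore expected in this assay, so compound 4 is estimated at 900 nM, within 450 nM to 2200 nM. This corresponds to an expected step of a 1.6-fold higher number from compound 2 to compound 4 (0.21 log units; within the scatter), with a real chance that the assay returns only a limit rather than a number.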

Compound 4, half-maximal inhibitory concentration: 46 nM
Compound 4: the middle estimate sits 20-fold (1.29 log units) above what was measured, and the stated range ends above it.
By their numbers in this assay, from the lowest: compound 4; then compounds 2 and 1 (each within the scatter of the next). At a limit, above all of these: compound 3.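

In this assay, putting 2,5-dimethylphenyl in place of 2-methoxyphenyl on a sulfonamide nitrogen gives a 12-fold lower number from compound 2 to compound 4 (1.08 log units; beyond the scatter), the only step shown that lies beyond the scatter, so this group can move the number a long way while the shared core stays the same. Replacing an oxygen-bearing group with an all-carbon one has no single direction here, since the other step shown, an at least 1.5-fold higher number from compound 1 to compound 3 (0.18 log units; that floor lies within the scatter), points toward a higher number, although its floor lies within the scatter and the groups involved differ. The entering and leaving groups have the same number of heavy atoms, and the entering one lacks the hydrogen-bond acceptor of the leaving one, but nothing measured here explains the gain.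

This single step removes a methoxy group and adds two methyl groups at once, so the compounds shown cannot tell whether one methyl group alone would give the same result or whether both are needed. They also leave open whether other small groups on this ring, such as chlorine, an amine or a carboxylic acid, would keep the number this low.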